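Bis-benzylidene cyclohexanones: fibroblast cytotoxicity notes

This account rests on a few compounds, and the source may have more. Where it says the series, first, only, none or still open, it means among the compounds named here.

Within the data shown here, compound 1 `COc1cccc(/C=C2\CCC/C(=C\c3cccc(Br)c3)C2=O)c1OC` and compound 2 `COc1ccc(/C=C2\CCC/C(=C\c3ccc(Cl)cc3)C2=O)cc1OC` are the two members measured so far. In an ADME assay on NHDF cells (Homo sapiens) for cytotoxicity, read by MTT assay, with a stated time of 72 h (a higher number here means a weaker inhibitor, a lower number a stronger inhibitor), compound 1 gives 23900 nM. In this assay compound 2 gives 11200 nM, the lowest of the two numbers, and compound 1 stands beyond the usual scatter above it. Among the measured compounds shown here, no pair differing in a single place has been measured, so no step size is known from this series.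

Compound 3 `COc1ccc(/C=C2\CCC/C(=C\c3ccc(O)c(O)c3)C2=O)cc1OC` is the next to be measured. It departs from compound 2 by 3,4-dihydroxyphenyl in place of 4-chlorophenyl on a double-bonded chain carbon bound to a double-bonded ring carbon. With nothing measured to guide the size of this change, the step from compound 2 to compound 3 is expected to be a 2.0-fold higher number from compound 2 to compound 3 (0.29 log units; within the scatter), an upward move beyond the scatter, toward weaker inhibition. For compound 3 the estimated value in this assay is 22000 nM, with a range from 7000 nM to 70000 nM.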

Compound 3, half-maximal inhibitory concentration: 25200 nM
Compound 3: middle estimate off by 1.1-fold (0.06 log units), on the low side; the range from low to high includes it.
By their numbers in this assay, from the lowest: compound 2; then compounds 1 and 3 (each within the scatter of the next).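

Notes on the series: replacing 4-chlorophenyl with 3,4-dihydroxyphenyl on a double-bonded chain carbon bound to a double-bonded ring carbon gives the first single-place step in this assay, a 2.3-fold higher number from compound 2 to compound 3 (0.35 log units; beyond the scatter), a modest move toward weaker inhibition. This shows that the number responds to a change at this position, which the earlier pair, differing in more than one place, could not show. Nothing available explains the size or direction of this step.

Among these compounds, the single step does not separate the loss of the chlorine from the gain of the hydroxyl groups, so a plain phenyl or a 4-hydroxyphenyl at this position remains an open comparison. Also open, as far as these compounds go, is whether an amine or a carboxylic acid on this ring would move the number further, and in which direction.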